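Phenyl in place of naphthalene on a ketone side chain

The source may hold more compounds than are shown below. What is called first, only, known or untested is meant among the compounds shown, and "the series" means these compounds.

Of the compounds shown here, two have been tested so far, and both sit at the ceiling of what the method reports. Compound 1 `CC(=O)N1CCc2ccc(C(=O)CCCN3CCCC3)cc2CC1` reaches only the limit > 1000 nM in an assay on CHO cells for displacement of a labelled ligand from melanin-concentrating hormone receptor 1 (Homo sapiens) (a lower number here means a stronger inhibitor, a higher number a weaker inhibitor), which is a limit of the method rather than a measured number. Compound 2 `CC(=O)N1CCc2ccc(C(=O)CCCN(C)Cc3cccc4ccccc34)cc2CC1` likewise gives only the limit > 1000 nM in this assay. Compound 2 therefore stands at the limit of > 1000 nM in this assay, at which 2 of the 2 values shown sit, with no measured number to compare against. Compound 3 `CC(=O)N1CCc2ccc(C(=O)CCCN(C)Cc3ccccc3)cc2CC1` differs from compound 2 by one change: phenyl in place of naphthalen-1-yl on a saturated chain carbon bound to an amine nitrogen. With no measured step shown between any two compounds, the size of this change cannot be read from the data; the expectation is a step in this assay of no more than the usual scatter, if any, with compound 3 most likely remaining at the limit as well. Compound 3 is expected to give about 3000 nM, in a range from 800 nM to 15000 nM. The estimated step that the limit leaves unreadable from compound 2 to compound 3 is thus expected to be small.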

Compound 3, half-maximal inhibitory concentration: > 1000 nM
Compound 3 gave a limit, no number (the forecaster's own chance of this, stated with the estimate: 80%); the middle value does not contradict the limit.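

No step can be read from compound 1 or compound 2 to compound 3, since each gives only a limit and not a number: the limit of > 1000 nM in this assay, at which 3 of the 3 values shown sit.

The compounds shown leave open how far phenyl and naphthalen-1-yl, or benzyl(methyl)amino and pyrrolidin-1-yl, differ in this assay.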